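Methyl in place of bromo: the step to compound 4

The source may report more compounds than this note shows. Statements on the series, on what has been measured and on what is new or still open speak of the compounds shown alone.

Compound 1 (`CCC/N=C1\S/C(=C\c2ccc(O)cn2)C(=O)N1c1ccccc1C`) gives 110000 nM
Compound 2 (`CCC/N=C1\S/C(=C\c2ccc(O)c(C(F)(F)F)c2)C(=O)N1c1ccccc1C`) gives 14000 nM
Compound 3 (`CCC/N=C1\S/C(=C\c2ccc(O)c(Br)c2)C(=O)N1c1ccccc1C`) gives 79000 nM

In a physicochemical assay for solubility, measured as kinetic solubility (on this read-out lower numbers stand for lower solubility and higher numbers for higher solubility), compound 3 gives 79000 nM and stays within the scatter of compound 1, with only compound 2 clearly lower. Compound 4 (`CCC/N=C1\S/C(=C\c2ccc(O)c(C)c2)C(=O)N1c1ccccc1C`) differs from compound 3 by methyl in place of bromo on an aromatic carbon and thus has methyl in place of bromo on an aromatic carbon, ortho to a hydroxy group. The closest measured change is a 5.6-fold higher number from compound 2 to compound 3 (0.75 log units; beyond the scatter) where bromo takes the place of trifluoromethyl. The other, a 1.4-fold lower number from compound 1 to compound 3 (0.14 log units; within the scatter) replaces the whole aromatic group and bears on this change less directly. Among the measured compounds shown here, no measured compound carries methyl there, so the expectation is loose. In this assay the expected result is a 1.3-fold lower number from compound 3 to compound 4 (0.12 log units; within the scatter) and so no step beyond the scatter. The estimated value of compound 4 is 60000 nM (range 25000 nM to 130000 nM).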

Compound 4, solubility: 78000 nM
Estimate against measurement, compound 4: 1.3-fold (0.11 log units) below, and the stated range covers the measured number.
By their numbers in this assay, from the lowest: compound 2; then compounds 4, 3 and 1 (each within the scatter of the next).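

In this assay, methyl and bromo on this aromatic carbon, ortho to a hydroxy group, cannot be told apart (a 1.0-fold lower number from compound 3 to compound 4 (0.01 log units; within the scatter)). Trifluoromethyl remains the only group at this position clearly separated from another (a 5.6-fold higher number from compound 2 to compound 4 (0.75 log units; beyond the scatter)), while the 4-hydroxy-3-methylphenyl group stays within the scatter of 5-hydroxypyridin-2-yl (a 1.4-fold lower number from compound 1 to compound 4 (0.15 log units; within the scatter)). Nothing available here explains these numbers. As far as these compounds go, whether an amine or a carboxylic acid on this aromatic carbon would keep the number in the same range remains open.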